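The compounds below may be only part of what the source reports. "The series", "measured", "known", "first", "only" and "open" are said of these compounds alone.

Compound 1 `Cc1cc(NC(=O)Nc2ccc(C)c(Cl)c2)c2ccccc2n1` gives > 25000 nM in an ADME assay on HEK293 cells (Homo sapiens) for cytotoxicity, with a stated time of 72 h; a higher number here means that more compound is needed for the effect, a lower number that less compound is needed; this is a limit of the assay, not a number.
Compound 2 `Cc1ccc(NC(=O)Nc2cc(C)nc3ccccc23)cc1` gives > 25000 nM in this assay, which is again a limit rather than a number.
Compound 3 `Cc1cc(NC(=O)Nc2ccccc2F)c2ccccc2n1` gives > 25000 nM in this assay, also a limit.

Compound 2 therefore stands at the limit of > 25000 nM in this assay, at which 3 of the 3 values shown sit, and no finer position for it is known. The two measured steps that touch compound 2 are a step that the two limits leave unreadable from compound 1 to compound 2 and a step that the two limits leave unreadable from compound 2 to compound 3; in both cases the limits hide the size of the step, so neither says how a change on the outer phenyl ring affects the read-out in this assay.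

The next compound, compound 4 `CC(=O)c1ccc(NC(=O)Nc2cc(C)nc3ccccc23)cc1`, differs from compound 2 by acetyl in place of methyl on an aromatic carbon. For the measured compounds named here, no measured step involves an acetyl group, so the expectation for compound 4 rests only on the fact that all three measured compounds sit at the limit. The step from compound 2 to compound 4 is expected to be a step that the limit leaves unreadable from compound 2 to compound 4, that is, no readable change beyond the scatter. Compound 4 is therefore estimated at 30000 nM in this assay, within a range from 10000 nM to 100000 nM, most likely reported only as a limit again.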

Compound 4, half-maximal effective concentration: > 25000 nM
Compound 4 was reported as a limit; the forecaster's own chance of this, stated with the estimate: 80%; the middle value lies beyond the limit too.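

In this assay compound 4 gives > 25000 nM, which is a limit and not a number. Compound 2 also sits at a limit, so the change from compound 2 to compound 4 has no readable size. The compounds shown leave open what concentration of any of them would produce the effect in this assay.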